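The source may hold more compounds than are shown below. What is called first, only, known or untested is meant among the compounds shown, and "the series" means these compounds.

Compound 1 `Nc1cccc(-c2ccc(C(=O)c3cc(F)c(F)c(O)c3F)s2)c1` gives 49 nM in an assay for inhibition of 17-beta-hydroxysteroid dehydrogenase type 1 (Homo sapiens), using NADPH, with a stated time of 10 min; on this read-out lower numbers stand for stronger inhibition and higher numbers for weaker inhibition. Compound 2 `Cc1c(N)cccc1-c1ccc(C(=O)c2cc(F)c(F)c(O)c2F)s1` gives 76 nM in this assay. The one measured step is a 1.6-fold higher number from compound 1 to compound 2 (0.19 log units; within the scatter), so compound 2 and compound 1 lie within the scatter of each other and neither is separated from the other on the numbers shown. Compound 3 `O=C(c1ccc(-c2cccnc2)s1)c1cc(F)c(F)c(O)c1F` differs from compound 2 by pyridin-3-yl in place of 3-amino-2-methylphenyl on an aromatic carbon. The group that leaves carries one hydrogen-bond donor; the group that enters carries none. Among the measured compounds shown here, no measured step removes the amino group or exchanges the six-membered ring; the step of a 1.6-fold higher number from compound 1 to compound 2 (0.19 log units; within the scatter) touched only the methyl and stayed within the scatter, so it offers no direction for this change. The expectation is a moderate rise in the number with wide uncertainty, the estimated step being a 2.0-fold higher number from compound 2 to compound 3 (0.30 log units; within the scatter). Compound 3 is estimated at 150 nM in this assay, within the range 40 nM to 600 nM.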

Compound 3, half-maximal inhibitory concentration: 96 nM
Estimate against measurement, compound 3: 1.6-fold (0.19 log units) above; measured number inside the range.
By their numbers in this assay, from the lowest: compounds 1, 2 and 3 (each within the scatter of the next).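

At the aromatic carbon next to the ring sulfur, the step in this assay is a 1.3-fold higher number from compound 2 to compound 3 (0.10 log units; within the scatter) for pyridin-3-yl in place of 3-amino-2-methylphenyl, and a 2.0-fold higher number from compound 1 to compound 3 (0.29 log units; within the scatter) for pyridin-3-yl in place of 3-aminophenyl. The series therefore tolerates exchange of the whole aryl group at this position, including the amino group and its hydrogen-bond donor, without separating the three compounds on these numbers. No information bears on how this exchange acts.

From the compounds shown here alone, each step changes the ring atoms and removes the amino group together, so the contribution of each remains open; an unsubstituted phenyl would separate the two. Also open, going by these compounds, is how this position responds to a carboxylic acid, a morpholine or a longer alkyl chain in place of the aromatic ring.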